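A few compounds are considered here, and "the series" means these few. Any claim that something is new, unique, unknown or untested is made for them only; others in the source may bear on it.

Compound 1 `C(=C\c1ccc2[nH]ccc2c1)\c1ccc2ccccc2c1`: > 5000 nM (a limit)
Compound 2 `Cn1ccc2cc(/C=C/c3ccc4ccccc4c3)ccc21`: > 5000 nM (a limit)

In a functional assay on SK-MEL-28 cells (Homo sapiens) for inhibition (on this read-out higher numbers stand for weaker inhibition and lower numbers for stronger inhibition), compound 2 gives only a limit, > 5000 nM, and no number. Compound 3 `Cn1ccc2cc(/C=C\c3ccc4ccccc4c3)ccc21` is not yet measured. It differs from compound 2 by the two compounds have the same atoms and bonds and differ only in configuration as drawn: 1 of 1 stereo elements differ; a double bond is drawn E in compound 2 and Z in compound 3. Within the data shown here, no measured step sets a size for this change, so the expectation is loose. The expected shift is an at least 2.5-fold lower number from compound 2 to compound 3 (0.39 log units; beyond the scatter), toward stronger inhibition, though another limit would be no surprise. For compound 3 the estimated value is 2000 nM, with an expected range of 200 nM to 8000 nM.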

Compound 3, half-maximal inhibitory concentration: > 5000 nM
Compound 3: only a limit was reported; the forecaster's own chance of this, stated with the estimate: 45%; at least 2.5-fold (0.39 log units) between middle value and limit.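

In this assay, the steps among compound 1, compound 2 and compound 3 cannot be read, as all three values are limits: the limit of > 5000 nM in this assay, at which 3 of the 3 values shown sit.

The compounds shown leave open whether double-bond configuration or methyl in place of hydrogen on an aromatic nitrogen alters inhibition at all.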